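The source may hold more compounds than are shown below. What is called first, only, known or untested is meant among the compounds shown, and "the series" means these compounds.

Measured so far:
compound 1, `O=C(O)CCn1c(=O)oc2cc(OCc3ccccc3)c(Cl)cc21`, 2.71
compound 2, `Cc1ccc([C@@H](C)Oc2cc3onc(CCC(=O)O)c3cc2Cl)nn1`, 2.97

In a physicochemical assay for lipophilicity, read by HPLC, at pH 7.4 (a higher number here means a more lipophilic compound, a lower number a more polar compound), compound 1 gives 2.71, the lower of the two numbers recorded. Compound 2 gives 2.97 in this assay, a number that sits within the usual scatter of compound 1, so the two cannot be told apart on these measurements.

Compound 3, `C[C@@H](Oc1cc2oc(=O)n(CCC(=O)O)c2cc1Cl)c1ncccn1`, has not yet been measured in this assay. It differs from compound 1 in one place: a group of 8 heavy atoms (6 carbon, 2 nitrogen; one six-membered aromatic ring with 2 hetero atoms) in place of a group of 7 heavy atoms (7 carbon; one six-membered aromatic ring of carbon only), on an oxygen on an aromatic ring. The ring that enters carries two hydrogen-bond acceptors where the benzyl group carried none, and it sits on the same oxygen on the aromatic ring.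

Among the measured compounds shown here, no step between measured compounds is available to calibrate this change, so the expectation rests on the change itself. A moderate step downward, beyond the scatter, is expected from compound 1 to compound 3, of about a number 0.71 log units lower from compound 1 to compound 3 (beyond the scatter). Compound 3 is therefore estimated at 2 in this assay, most likely between 1.4 and 2.6.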

Compound 3, distribution coefficient: 0.83
Compound 3: the middle estimate sits 1.17 log units above what was measured; measured number outside the range, below it.
By their numbers in this assay, from the lowest: compound 3; then compounds 1 and 2 (each within the scatter of the next).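

In this assay, replacing benzyl on an oxygen on an aromatic ring with a group carrying a six-membered aromatic ring with 2 hetero atoms gives a number 1.88 log units lower from compound 1 to compound 3 (beyond the scatter) and this is the first change shown to lie clearly beyond the scatter. It shows that the number at this position can respond strongly to a single change while the rest of compound 1 stays the same. The data at hand offer no explanation for the size of this step.

The entering group differs from benzyl in both its ring and its 1 defined stereocentre, so this single step cannot be divided between those two differences. The compounds shown include no pyridine ring, with its single ring nitrogen, on this oxygen, so the effect of one ring nitrogen rather than two stays open.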